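A dimethylamino swap at the assay limit

The source may report more compounds than this note shows. Statements on the series, on what has been measured and on what is new or still open speak of the compounds shown alone.

Compound 1 `CC(=O)Oc1ccc(/C=C/c2ccc3ccccc3c2)cc1` gives > 5000 nM (a limit)
Compound 2 `Cc1ccc(/C=C/c2ccc3ccccc3c2)cc1` gives > 5000 nM (a limit)
Compound 3 `FC(F)(F)c1ccc(/C=C/c2ccc3ccccc3c2)cc1` gives > 5000 nM (a limit)

In a functional assay on A549 cells (Homo sapiens) for inhibition (on this read-out lower numbers stand for stronger inhibition and higher numbers for weaker inhibition), compound 3 stands at > 5000 nM, which is a limit and not a number. The other two compounds offer no number either (the limit of > 5000 nM in this assay, at which 3 of the 3 values shown sit).

Compound 4 `CN(C)c1ccc(/C=C/c2ccc3ccccc3c2)cc1` carries dimethylamino in place of trifluoromethyl on an aromatic carbon, para to a large group (dimethylamino in place of trifluoromethyl on an aromatic carbon). The measured steps that bear on this change are a step that the two limits leave unreadable from compound 1 to compound 3 and a step that the two limits leave unreadable from compound 2 to compound 3, along with a step that the two limits leave unreadable from compound 1 to compound 2. None of them gives a size or a direction, and dimethylamino has not been measured on this core, so any expectation here is weak. The likeliest outcome in this assay is another result reported only as a limit. The expected change, as a rough estimate, is a step that the limit leaves unreadable from compound 3 to compound 4 and could go either way. For compound 4 the estimated value is 7000 nM (expected range 2000 nM to 25000 nM).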

Compound 4, half-maximal inhibitory concentration: 3660 nM
The estimate for compound 4 lay 1.9-fold (0.28 log units) above the measured number; the measured number falls inside the stated range.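

In this assay, compound 4 is the only compound shown that gives a number rather than a limit, so dimethylamino on this aromatic carbon is the one group here that brings the read-out inside the measurable range: the limit of > 5000 nM in this assay, at which 3 of the 4 values shown sit.

Set against those limits, the change gives an at least 1.3-fold lower number from compound 3 to compound 4 (0.13 log units; that floor lies within the scatter), an at least 1.3-fold lower number from compound 2 to compound 4 (0.13 log units; that floor lies within the scatter) and an at least 1.3-fold lower number from compound 1 to compound 4 (0.13 log units; that floor lies within the scatter). Each of these is only a floor, so the real gaps may be larger, but the data do not show a change beyond the scatter, and the steps among the three earlier compounds cannot be read.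

The compounds shown leave open whether a simple amino group, diethylamino or a carboxylic acid on this carbon would lower the number further. On these data alone, the true values of compound 1, compound 2 and compound 3 also remain unknown.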